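This account rests on a few compounds, and the source may have more. Where it says the series, first, only, none or still open, it means among the compounds named here.

Measured compounds in this set:
compound 1 `Cc1cccc(-n2nncc2CN2C(=O)C3(C(C#N)=C(N)Oc4c3c3nc5ccccc5nc3c3ccccc43)c3ccccc32)c1`
compound 2 `N#CC1=C(N)Oc2c(c3nc4ccccc4nc3c3ccccc23)C12C(=O)N(Cc1cnnn1-c1ccc(F)cc1)c1ccccc12`
compound 3 `N#CC1=C(N)Oc2c(c3nc4ccccc4nc3c3ccccc23)C12C(=O)N(Cc1cnnn1-c1ccccc1Br)c1ccccc12`

In a functional assay on HCT-116 cells (Homo sapiens) for antiproliferative activity, read by MTT assay, with a stated time of 48 h (a higher number here means a weaker inhibitor, a lower number a stronger inhibitor), compound 1 gives > 50000 nM, which is a limit of the assay and not a number. In this assay compound 2 gives > 50000 nM, likewise a limit. In this assay compound 3 gives > 50000 nM, again only a limit.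

Compound 3 therefore stands where every measured value of the series stands (the limit of > 50000 nM in this assay, at which 3 of the 3 values shown sit). The changes of the aryl group on the aromatic nitrogen, from compound 1 to compound 2 a step that the two limits leave unreadable from compound 1 to compound 2, from compound 1 to compound 3 a step that the two limits leave unreadable from compound 1 to compound 3 and from compound 2 to compound 3 a step that the two limits leave unreadable from compound 2 to compound 3, are all unreadable in size, since both ends of each step are limits.

The next compound is compound 4 `CCOc1ccc(-n2nncc2CN2C(=O)C3(C(C#N)=C(N)Oc4c3c3nc5ccccc5nc3c3ccccc43)c3ccccc32)cc1`. The change from compound 3 is 4-ethoxyphenyl in place of 2-bromophenyl on an aromatic nitrogen. All three measured steps bear on it in kind, as each swaps the aryl group on the same aromatic nitrogen, but none gives a readable size, and all measured values sit at the limit (the limit of > 50000 nM in this assay, at which 3 of the 3 values shown sit). No shift beyond the scatter is expected in this assay; the expected step is a step that the limit leaves unreadable from compound 3 to compound 4, read against a limit. For compound 4 the estimate is 70000 nM, with a range from 30000 nM to 200000 nM, most probably reported again as a limit.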

Compound 4, half-maximal inhibitory concentration: > 50000 nM
Compound 4: only a limit was reported (the forecaster's own chance of this, stated with the estimate: 80%); the middle value lies beyond the limit too.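

No new step can be read in this assay between compound 4 and compound 1, compound 2 or compound 3, because both ends of each step are limits and not numbers: the limit of > 50000 nM in this assay, at which 4 of the 4 values shown sit.

The compounds shown leave open whether any aryl group on this aromatic nitrogen changes the antiproliferative activity at all, and how large such a change would be.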